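Amine substituent variation on a shared core

A few compounds are considered here, and "the series" means these few. Any claim that something is new, unique, unknown or untested is made for them only; others in the source may bear on it.

The shared core is carried unchanged across the series. Within the data shown here, compound 1 `CSc1nc(-c2ccc(F)cc2)c(-c2ccnc(NC3CCCCC3C)c2)[nH]1` is the only member with a result: in a functional assay on blood (Homo sapiens) for inhibition (on this read-out lower numbers stand for stronger inhibition and higher numbers for weaker inhibition), compound 1 gives 136 nM. Compound 2 `CSc1nc(-c2ccc(F)cc2)c(-c2ccnc(NC3CCc4ccccc43)c2)[nH]1` has no result; its entry in this assay reads "not determined" (no result reported), so compound 2 stands nowhere on the numbers shown and no measured step can start from it. Compound 3 `CCC(Nc1cc(-c2[nH]c(SC)nc2-c2ccc(F)cc2)ccn1)c1ccccc1` has not yet been measured. It differs from compound 2 at one place only: 1-phenylpropyl in place of 2,3-dihydro-1H-inden-1-yl on a nitrogen on an aromatic ring. The group that enters keeps the same count of heavy atoms and the same six-membered aromatic ring of carbon only, while the five-membered non-aromatic ring is gone. With no value for compound 2 and a single number for compound 1, the step from compound 2 to compound 3 in this assay cannot be sized from measurements; the expectation is for no step beyond the scatter in either direction. Compound 3 is expected to give 150 nM in this assay, with a range from 40 nM to 600 nM. Among the measured compounds shown here, the anchor is compound 1 because 136 nM is the only number in hand.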

Compound 3, half-maximal inhibitory concentration: 7640 nM
Compound 3: the middle estimate sits 51-fold (1.71 log units) below what was measured; the measured number lies above the stated range.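

In this assay, among these compounds, this position on the shared core proves sensitive to the group on the nitrogen: 1-phenylpropyl in place of 2-methylcyclohexyl on a nitrogen on an aromatic ring gives a 56-fold higher number from compound 1 to compound 3 (1.75 log units; beyond the scatter) and so sets a large step at a place where compound 1 alone gave only a single number. The step from compound 2 to compound 3 cannot be read, since compound 2 has no number, and the loss of the five-membered non-aromatic ring therefore stays unsized, with no measured answer on whether the fused ring of compound 2 behaves more like the group of compound 3 or otherwise. No measurement at hand bears on what lies behind the step.

Among the compounds shown here, the single step changes a saturated ring for a chain carrying a six-membered aromatic ring of carbon only, so it cannot say which part of that change carries the effect, and a cyclohexyl without the methyl, a cyclohexylmethyl or a benzyl on the same nitrogen would start to separate them. Also open, from the compounds shown here alone, is whether a shorter 1-phenylethyl or a hydroxyl on the 2-methylcyclohexyl ring would hold the number near that of compound 1 or near that of compound 3.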